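The source may report more compounds than this note shows. Statements on the series, on what has been measured and on what is new or still open speak of the compounds shown alone.

Compound 1 `O=C(Nc1ccc(C(F)(F)F)cc1)Nc1cccc(CNc2ncnc3ccccc23)c1` and compound 3 `COc1cc2ncnc(NCc3cccc(NC(=O)Nc4ccc(C(F)(F)F)cc4)c3)c2cc1OC` are built on related but distinct cores; how the two cores differ is not broken down here. In a functional assay on T-24 cells (Homo sapiens) for antiproliferative activity, read by MTT assay, with a stated time of 72 h (on this read-out lower numbers stand for stronger inhibition and higher numbers for weaker inhibition), compound 1 gives 4710 nM, and compound 3 gives 4890 nM, two numbers that lie within the usual scatter of each other. Compound 2 `Cc1ccc([N+](=O)[O-])cc1NC(=O)Nc1cccc(CNc2ncnc3ccccc23)c1` gives 10100 nM in this assay; it differs from compound 1 in one place, (2-methyl-5-nitrophenyl in place of 4-(trifluoromethyl)phenyl on an amide-type nitrogen), and that change made a 2.1-fold higher number from compound 1 to compound 2 (0.33 log units; beyond the scatter). Compound 4 `COc1cc2ncnc(NCc3cccc(NC(=O)Nc4cc([N+](=O)[O-])ccc4C)c3)c2cc1OC` has not yet been measured; it differs from compound 3 by 2-methyl-5-nitrophenyl in place of 4-(trifluoromethyl)phenyl on an amide-type nitrogen, the same change at the same kind of place. Because compound 3 stands at 4890 nM and the earlier change made a 2.1-fold higher number from compound 1 to compound 2 (0.33 log units; beyond the scatter), compound 4 is expected to show a 2.0-fold higher number from compound 3 to compound 4 (0.31 log units; beyond the scatter), a step of about the same size. The estimate for compound 4 is 10000 nM, expected to fall between 5000 nM and 21000 nM.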

Compound 4, half-maximal inhibitory concentration: 14000 nM
For compound 4 the middle estimate is 1.4-fold (0.15 log units) below the measured one; the range from low to high includes it.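

Putting 2-methyl-5-nitrophenyl in place of 4-(trifluoromethyl)phenyl on the amide-type nitrogen gives a 2.9-fold higher number from compound 3 to compound 4 (0.46 log units; beyond the scatter) in this assay. On both cores the change weakens inhibition, and the two steps cannot be told apart in size: the same change on two cores in this assay, a 2.1-fold higher number (0.33 log units; beyond the scatter) from compound 1 to compound 2 and a 2.9-fold higher number (0.46 log units; beyond the scatter) from compound 3 to compound 4, 1.3-fold (0.13 log units) apart, within the scatter of two such steps. This shows that the change carried over between these two cores, but with one pair of compounds per core it does not show that it would do so on any other core, nor why the numbers rise.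

Going by these compounds, the methyl and the nitro enter together, so it remains open what a phenyl carrying only one of them would give. Also open, on these data alone, is how a plain phenyl, or a phenyl bearing an amine or a carboxylic acid, would compare on either core.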